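A few compounds are considered here, and "the series" means these few. Any claim that something is new, unique, unknown or untested is made for them only; others in the source may bear on it.

Compound 1 `O=C(N/N=C/c1ccccc1)c1cnccn1` stands highest of the two numbers in an ADME assay on J774 cells (Mus musculus) for cytotoxicity, read by MTT assay, with a stated time of 48 h, tested at 50 ug/mL (on this read-out higher numbers stand for a weaker effect at the one concentration tested and lower numbers for a stronger effect), where compound 1 gives 100%. Its nearest neighbour, compound 2 `O=C(N/N=C/c1ccccc1Cl)c1cnccn1`, gives 70% in this assay. Within the data shown here, the single measured step that bears on the question is a number 30 percentage points lower from compound 1 to compound 2 (beyond the scatter), a chloro entering elsewhere on the same ring. Compound 3 `O=C(N/N=C/c1cccc(Cl)c1)c1cnccn1` differs from compound 1 by chloro in place of hydrogen on an aromatic carbon. Because the step to compound 2 was a number 30 percentage points lower from compound 1 to compound 2 (beyond the scatter), a lowering of similar size is expected for compound 3 in this assay: a number 25 percentage points lower from compound 1 to compound 3 (beyond the scatter). Compound 3 is therefore estimated at 75%, with a range from 55% to 100%.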

Compound 3, a percentage reported as activity, at one concentration (the size of the read-out at that concentration, not a potency): 100%
The estimate for compound 3 lay 25 percentage points below the measured number; the measured number falls inside the stated range.
By their numbers in this assay, from the lowest: compound 2; then compounds 1 and 3 (each within the scatter of the next).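

In this assay, chloro in place of hydrogen on an aromatic carbon, meta to a large group, gives no change at the digits printed from compound 1 to compound 3 (within the scatter) and so leaves this position without a measurable cost. The same replacement therefore does not act alike at every carbon of this ring: compound 2, with its chloro elsewhere, gives 70% while compound 3 gives 100% in the same test. Nothing measured here explains this difference. As far as these compounds go, whether a methoxy group or an amine at this carbon would also match compound 1 remains open.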